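The source may report more compounds than this note shows. Statements on the series, on what has been measured and on what is new or still open speak of the compounds shown alone.

Compound 1 `CCc1nc2c(-c3ccc(Cl)cc3Cl)ccnc2n1[C@H](CC)C1CC1` was tested in an assay for binding affinity to Corticotropin releasing factor receptor (Rattus norvegicus) (a higher number here means a weaker inhibitor, a lower number a stronger inhibitor), and in it compound 1 gives 0.2 nM. Among the measured compounds shown here, that is the lower of the two numbers known so far; compound 2 `CCCC(C)n1c(CC)nc2c(-c3ccc(C(F)(F)F)cc3Cl)ccnc21` gives 1.1 nM in this assay, and the gap between them lies beyond the usual scatter of repeat measurements. Compound 3 `CCc1nc2c(-c3ccc(Cl)cc3Cl)ccnc2n1C(CC)CC` has not yet been measured in this assay. It differs from compound 1 in one place: pentan-3-yl in place of 1-cyclopropylpropyl on an aromatic nitrogen. For the measured compounds named here, no pair of measured compounds shows this exact change, so the expectation rests only on how close the two structures are. The expected step of a 2.0-fold higher number from compound 1 to compound 3 (0.30 log units; within the scatter) is small, at most a slightly higher number, and is not expected to reach beyond the scatter. Compound 3 is therefore estimated to give 0.4 nM in this assay, with a range from 0.1 nM to 1.5 nM.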

Compound 3, inhibition constant: 1 nM
For compound 3 the middle estimate is 2.5-fold (0.40 log units) below the measured one, within the range that was stated.
By their numbers in this assay, from the lowest: compound 1; then compounds 3 and 2 (each within the scatter of the next).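

In this assay, putting pentan-3-yl in place of 1-cyclopropylpropyl on the aromatic nitrogen gives a 5.0-fold higher number from compound 1 to compound 3 (0.70 log units; beyond the scatter). This position therefore does not treat these two carbon-only groups alike, even though neither carries a hydrogen-bond donor, a hydrogen-bond acceptor or a net charge. The change takes away the three-membered ring and the defined stereocentre together, so this single step cannot show which of the two matters, or whether both do.

Still open, going by these compounds, is whether a cyclobutyl group or a longer chain on this nitrogen would give a number closer to that of compound 1 or to that of compound 3, and how the other stereoisomer of compound 1 would compare. No measurement at hand accounts for the size of this step.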